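The source may hold more compounds than are shown below. What is called first, only, known or untested is meant among the compounds shown, and "the series" means these compounds.

Measured so far:
compound 1 `CCc1cccc(N2CCNC(=O)N2)c1` — 13000 nM
compound 2 `CC1CN(c2cccc(F)c2)NC(=O)N1` — 6300 nM
compound 3 `CC1CN(c2cccc(F)n2)NC(=O)N1` — 6600 nM

In an assay on RBL-1 cells for inhibition of Polyunsaturated fatty acid 5-lipoxygenase (Rattus norvegicus) (on this read-out lower numbers stand for stronger inhibition and higher numbers for weaker inhibition), compound 3 stands second highest of the three numbers, yet both neighbours sit within the scatter: compound 2 differs by almost nothing, and compound 1 lies only at the edge of the usual spread. Compound 4 `CC1CN(c2cccc(Br)n2)NC(=O)N1` follows from compound 3 by a single change, (bromo in place of fluoro on an aromatic carbon). Among the measured compounds shown here, no measured pair shows this swap, so there is nothing to size the step from. The expectation is therefore a step from compound 3 to compound 4 of no more than the scatter, a 1.3-fold lower number from compound 3 to compound 4 (0.12 log units; within the scatter), in either direction. For compound 4 the estimate in this assay is 5000 nM, with a range from 1500 nM to 16000 nM.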

Compound 4, half-maximal inhibitory concentration: 2400 nM
The estimate for compound 4 lay 2.1-fold (0.32 log units) above the measured number; measured number inside the range.
By their numbers in this assay, from the lowest: compound 4; then compounds 2, 3 and 1 (each within the scatter of the next, the first and the last beyond it).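

In this assay, among the compounds shown here, bromo in place of fluoro on an aromatic carbon next to the ring nitrogen gives a 2.8-fold lower number from compound 3 to compound 4 (0.44 log units; beyond the scatter) and so shows that the number responds to which halogen stands at this position, something the earlier compounds could not show. Nothing measured here accounts for the step. The compounds shown leave open whether chloro would fit the same trend, and whether a group other than a halogen, such as an amine or a nitrile, would be tolerated at this position. Also open, going by these compounds, is whether the same swap would carry over to the ring of compound 2, which has no ring nitrogen.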